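Chloro to Amino on the Shared Core

A few compounds are considered here, and "the series" means these few. Any claim that something is new, unique, unknown or untested is made for them only; others in the source may bear on it.

Compound 1 `CN(C)c1ncnc2c1ncn2COCCO` gives 400 ug/mL in a functional assay (Oryctolagus cuniculus) for inhibition; a lower number here means a stronger inhibitor, a higher number a weaker inhibitor. Compound 2 `Nc1nc2c(nc(Cl)n2COCCO)c(=O)[nH]1` reaches only a limit of this assay, reported as > 400 ug/mL, so no number is known for it. Compound 2 sits at the limit of > 400 ug/mL in this assay, at which 1 of the 2 values shown sits. One change leads on from it: amino in place of chloro on an aromatic carbon gives compound 3 `Nc1nc2c(nc(N)n2COCCO)c(=O)[nH]1`, not yet measured in this assay. Among the compounds with values here, no measured pair shows what this change does, and compound 2 offers only a limit as a starting point. The step of a number no higher from compound 2 to compound 3 (the limit leaves the size open) is expected to stay within the usual scatter. Compound 3 is therefore estimated at 400 ug/mL, within 100 ug/mL to 1600 ug/mL.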

Compound 3, concentration for 50% inhibition: 290 ug/mL
Estimate against measurement, compound 3: 1.4-fold (0.14 log units) above; measured number inside the range.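

With amino in place of chloro on this aromatic carbon, between two ring nitrogen atoms, the change gives an at least 1.3-fold lower number from compound 2 to compound 3 (0.13 log units; that floor lies within the scatter) in this assay. Compound 2 remains a limit and not a number: the limit of > 400 ug/mL in this assay, at which 1 of the 3 values shown sits. From the compounds shown here alone, the size of the step therefore stays unknown, and its floor alone does not separate amino from chloro at this position.

The compounds shown leave open what a methylamino group or a bromine atom would do on the same carbon. They also leave open whether a longer chain in place of the (2-hydroxyethoxy)methyl group would change the reading.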